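The source may report more compounds than this note shows. Statements on the series, on what has been measured and on what is new or still open speak of the compounds shown alone.

Two compounds of the series carry a number in a functional assay on HCT-116 cells (Homo sapiens) for cytotoxicity, read by MTT assay, with a stated time of 48 h; on this read-out higher numbers stand for weaker inhibition and lower numbers for stronger inhibition. Compound 1 `Cc1nc2c3ccccc3ccc2c2nc3c(ccc4ccccc43)c(-c3ccccc3Cl)c12` gives 48200 nM, and compound 2 `Cc1nc2c3ccccc3ccc2c2nc3c(ccc4ccccc43)c(-c3ccc(O)cc3)c12` gives 3190 nM, so compound 2 holds the lower of the two, with the step of a 15-fold lower number from compound 1 to compound 2 (1.18 log units; beyond the scatter). Compound 3 `Cc1ccc(-c2c3ccc4ccccc4c3nc3c2c(C)nc2c4ccccc4ccc32)cc1` differs from compound 2 by methyl in place of hydroxy on an aromatic carbon. Within the data shown here, no measured step swaps a hydroxy for a methyl; the single step at hand exchanges the whole aryl group and bears only loosely on this change. For compound 3 the expected move is upward, a 3.1-fold higher number from compound 2 to compound 3 (0.50 log units; beyond the scatter). Compound 3 is estimated at 10000 nM, range 3000 nM to 40000 nM.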

Compound 3, half-maximal inhibitory concentration: 67000 nM
Beside the measured number, compound 3's estimate is 6.7-fold (0.83 log units) below it, and the stated range ends below it.
By their numbers in this assay, from the lowest: compound 2; then compounds 1 and 3 (each within the scatter of the next).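

In this assay, exchanging only hydroxy for methyl gives a 21-fold higher number from compound 2 to compound 3 (1.32 log units; beyond the scatter) on the otherwise unchanged 4-hydroxyphenyl group, so the low number of compound 2 depends on this single group and not on the aryl exchange as a whole. The two non-hydroxy aryl groups are not separated, with a 1.4-fold higher number from compound 1 to compound 3 (0.14 log units; within the scatter) in this series. Nothing measured here accounts for the size of the step.

Open, from the compounds shown here alone, is whether a methoxy group or an amine on the same aromatic carbon would keep the number of compound 2. Also open, going by these compounds, is whether a hydroxy elsewhere on the ring would do so.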